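Swapping the tert-butyl amide for a pyridinyl amide

The source may hold more compounds than are shown below. What is called first, only, known or untested is meant among the compounds shown, and "the series" means these compounds.

Of the compounds shown here, three sharing one core have been measured in a functional assay on KB cells (Homo sapiens) for cytotoxicity; on this read-out higher numbers stand for weaker inhibition and lower numbers for stronger inhibition. Compound 1 `COc1ccc(S(=O)(=O)N2CCc3cccc(NC(=O)C(C)(C)C)c32)cc1` gives 359 nM, the second highest of the three numbers. Compound 2 `COc1ccc(S(=O)(=O)N2CCc3cccc(NS(=O)(=O)c4ccc(F)cc4)c32)cc1` gives 1200 nM, and compound 3 `COc1ccc(S(=O)(=O)N2CCc3cccc(NC(=O)c4ccc([N+](=O)[O-])cc4)c32)cc1` gives 102 nM. The steps out of compound 1 run both ways: a 3.3-fold higher number from compound 1 to compound 2 (0.52 log units; beyond the scatter), whereas a 3.5-fold lower number from compound 1 to compound 3 (0.55 log units; beyond the scatter).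

Compound 4 `COc1ccc(S(=O)(=O)N2CCc3cccc(NC(=O)c4ccncc4)c32)cc1` has not yet been measured in this assay. It differs from compound 1 in one place: pyridin-4-yl in place of tert-butyl on a carbonyl carbon. The step from compound 1 to compound 3 bears most directly on it, since there too the tert-butyl on the carbonyl carbon gave way to a six-membered aromatic ring, and that step lowered the number beyond the scatter. Because a 3.5-fold lower number from compound 1 to compound 3 (0.55 log units; beyond the scatter) was modest, a similar, modest lowering is expected here, a 2.2-fold lower number from compound 1 to compound 4 (0.35 log units; beyond the scatter). Compound 4 is therefore estimated at 160 nM, with a range from 60 nM to 450 nM.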

Compound 4, half-maximal inhibitory concentration: 9.6 nM
Estimate against measurement, compound 4: 17-fold (1.22 log units) above, outside the stated range (below it).
By their numbers in this assay, from the lowest: compound 4; then compound 3; then compound 1; then compound 2.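

At the carbonyl carbon, the result shows that the choice of aromatic ring can move the read-out much further than compound 3 suggested: in this assay the change from tert-butyl to pyridin-4-yl gives a 37-fold lower number from compound 1 to compound 4 (1.57 log units; beyond the scatter) and so places compound 4 lowest of the four. A six-membered aromatic ring on the carbonyl carbon is therefore not enough to account for the number, as pyridin-4-yl in place of 4-nitrophenyl still gives an 11-fold lower number from compound 3 to compound 4 (1.03 log units; beyond the scatter) and (pyridin-4-yl)carbonyl in place of (4-fluorophenyl)sulfonyl on the nitrogen gives a 130-fold lower number from compound 2 to compound 4 (2.10 log units; beyond the scatter) on the same read-out. No measurement in hand explains these differences.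

The compounds shown do not separate the part played by the ring nitrogen from that of the ring itself, which a plain phenyl on the carbonyl carbon would address. They also leave open how pyridin-3-yl or pyridin-2-yl would read there.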